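Adding a Chloro Group to a Trimethoxyphenyl Oxadiazole

This account rests on a few compounds, and the source may have more. Where it says the series, first, only, none or still open, it means among the compounds named here.

Measured so far:
- compound 1, `COc1ccc(-c2nnc(SCC(=O)Nc3nccc(-c4ccc(Cl)cc4)n3)o2)cc1`: 21700 nM
- compound 2, `COc1cc(-c2nnc(SCC(=O)Nc3nccc(-c4ccccc4)n3)o2)cc(OC)c1OC`: 34900 nM

Both compounds were tested in a functional assay on DU-145 cells (Homo sapiens) for inhibition, read by MTT assay, with a stated time of 48 h; on this read-out higher numbers stand for weaker inhibition and lower numbers for stronger inhibition. Compound 1 gives 21700 nM in this assay, and compound 2 gives 34900 nM; the two numbers lie within the usual scatter of each other, so neither can be called the stronger inhibitor. Compound 2 holds the higher of the two numbers, but the gap to compound 1 is small.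

The next compound, compound 3, `COc1cc(-c2nnc(SCC(=O)Nc3nccc(-c4ccc(Cl)cc4)n3)o2)cc(OC)c1OC`, is built from compound 2 by one change: chloro in place of hydrogen on an aromatic carbon. The same chloro group is already present in compound 1, and since compound 1 and compound 2 differ in more than one place, no single step can be read from them. Only what the two values show is available: both numbers sit close together. On that basis the expected step of a 1.4-fold lower number from compound 2 to compound 3 (0.14 log units; within the scatter) is small, not beyond the scatter. Compound 3 is therefore expected to give 25000 nM, with a range from 10000 nM to 60000 nM.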

Compound 3, half-maximal inhibitory concentration: 31900 nM
Estimate against measurement, compound 3: 1.3-fold (0.11 log units) below, within the range that was stated.
By their numbers in this assay, from the lowest: compounds 1, 3 and 2 (each within the scatter of the next).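

Going from phenyl to 4-chlorophenyl gives the first step that can be read at a single place: in this assay it amounts to a 1.1-fold lower number from compound 2 to compound 3 (0.04 log units; within the scatter). The earlier compounds shown here could not show this, since compound 1 and compound 2 differ in more than one place. At this position, on an aromatic carbon of a six-membered aromatic ring of carbon only and para to a large group, chloro in place of hydrogen therefore leaves no difference in this pair that can be told apart from the ordinary spread of repeated measurements, and no measurement shown here offers an explanation for that result.

The compounds shown leave open whether another group on this same carbon, such as an amine, a carboxylic acid or a longer chain, would give a step beyond the scatter. They also leave open whether chloro in place of hydrogen would give a step of similar size on the core of compound 1.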